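This account rests on a few compounds, and the source may have more. Where it says the series, first, only, none or still open, it means among the compounds named here.

Three compounds share the same core and differ only in the aryl group on the saturated ring carbon. Compound 1 `COc1cc(C2=NN(C(C)=O)C(c3ccc(F)c(F)c3)O2)cc(OC)c1OC` carries a 3,4-difluorophenyl group, compound 2 `COc1cc(C2=NN(C(C)=O)C(c3ccc(F)cc3)O2)cc(OC)c1OC` a 4-fluorophenyl group, and compound 3 `COc1cc(C2=NN(C(C)=O)C(c3ccccc3F)O2)cc(OC)c1OC` a 2-fluorophenyl group. In a functional assay on BGC-823 cells (Homo sapiens) for antiproliferative activity, read by MTT assay, tested at 5 uM (on this read-out lower numbers stand for a weaker effect and higher numbers for a stronger effect at the one concentration tested), compound 1 gives 21.6%, compound 2 gives 13.3%, and compound 3 gives 32.8%. Compound 3 stands highest of the three: the step of a number 11.2 percentage points higher from compound 1 to compound 3 (beyond the scatter) and the step of a number 19.5 percentage points higher from compound 2 to compound 3 (beyond the scatter) are both beyond the scatter, whereas the step of a number 8.3 percentage points lower from compound 1 to compound 2 (within the scatter) is not.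

Compound 4 `COc1cc(C2=NN(C(C)=O)C(c3c(Cl)cccc3Cl)O2)cc(OC)c1OC` takes the next step from compound 3: 2,6-dichlorophenyl in place of 2-fluorophenyl on a saturated ring carbon. The measured steps that bear on this change are the two that end in compound 3, and both show a modest rise on moving a fluorine to the 2-position of the phenyl ring. No measured compound carries chlorine, and none carries two substituents flanking the attachment point, so how the 2,6-dichlorophenyl group will compare with the 2-fluorophenyl group is not shown by these data. Compound 4 is therefore expected to give a number near that of compound 3, with a step of a number 3.2 percentage points higher from compound 3 to compound 4 (within the scatter) in this assay that may fall within the scatter. The estimate for compound 4 is 36%, in a range from 16% to 56%.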

Compound 4, a percentage reported as inhibition, at one concentration (the size of the read-out at that concentration, not a potency): 15.9%
Compound 4: middle estimate off by 20.1 percentage points, on the high side, outside the stated range (below it).
By their numbers in this assay, from the lowest: compounds 2, 4 and 1 (each within the scatter of the next); then compound 3.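

In this assay, the change from 2-fluorophenyl to 2,6-dichlorophenyl on the saturated ring carbon gives a number 16.9 percentage points lower from compound 3 to compound 4 (beyond the scatter) and so shows that this position does not simply reward a halogen at the 2-position of the phenyl ring, since the earlier compounds had shown only the gain with a single fluorine there. The new group also brings the number back among those of the other two aryl groups, with a number 2.6 percentage points higher from compound 2 to compound 4 (within the scatter) and a number 5.7 percentage points lower from compound 1 to compound 4 (within the scatter) in the same assay, which leaves compound 3 alone at the top of the four. Nothing measured on these compounds accounts for the loss, so the data give no reason for it.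

This one change swaps fluorine for chlorine and adds a second substituent together, so the compounds shown leave open which of the two goes with the lower number. A 2-chlorophenyl or a 2,6-difluorophenyl group at the same carbon would separate the two, and a 2-methoxyphenyl group would show whether a halogen is needed at all.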